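The source may report more compounds than this note shows. Statements on the series, on what has been measured and on what is new or still open speak of the compounds shown alone.

Values in an assay on isolated protein for inhibition of protein kinase C zeta type (Homo sapiens), with a stated time of 4 min, tested at 62.5 uM (on this read-out lower numbers stand for less inhibition and higher numbers for more inhibition at the one concentration tested (going by the name of the read-out)), for the three measured compounds:

compound 1 `CC(C)(C)C1=NN(c2ccccc2F)C(c2ccc(O)cc2)C1` gives 57.6%
compound 2 `CC(C)(C)C1=NN(c2c(Cl)cccc2Cl)C(c2ccc(O)cc2)C1` gives 65.5%
compound 3 `Oc1ccc(C2CC(c3ccccc3O)=NN2c2ccc(Cl)cc2)cc1` gives 92%

Compound 3 stands highest of the three numbers in this assay, with compound 2 nearest and compound 1 furthest, both gaps beyond the scatter. Among the measured compounds shown here, the one step between measured compounds that differ in a single place, a number 7.9 percentage points higher from compound 1 to compound 2 (within the scatter), lies within the scatter and concerns the aryl group on the ring nitrogen, not the carbon that carries the double bond to nitrogen.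

Compound 4 `CC1=NN(c2ccc(Cl)cc2)C(c2ccc(O)cc2)C1` is not yet measured. Its difference from compound 3 is methyl in place of 2-hydroxyphenyl on a carbon with a double bond to nitrogen. For the measured compounds named here, no measured step bears directly on this change: compounds 1 and 2 carry tert-butyl rather than methyl at that carbon and differ from compound 3 in their aryl group on the ring nitrogen as well, so their values only show that alkyl-bearing members sit well below compound 3. On that basis a downward step from compound 3 is expected, beyond the scatter and of a size near a number 42 percentage points lower from compound 3 to compound 4 (beyond the scatter). Compound 4 is therefore estimated at 50% in this assay, with a range from 25% to 75%.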

Compound 4, a percentage reported as inhibition, at one concentration (the size of the read-out at that concentration, not a potency): 58.8%
Estimate against measurement, compound 4: 8.8 percentage points below, and the stated range covers the measured number.
By their numbers in this assay, from the lowest: compounds 1, 4 and 2 (each within the scatter of the next); then compound 3.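

In this assay, among the compounds shown here, methyl in place of 2-hydroxyphenyl on the carbon with a double bond to nitrogen gives a number 33.2 percentage points lower from compound 3 to compound 4 (beyond the scatter) with the 4-chlorophenyl and 4-hydroxyphenyl groups held fixed, the first direct reading at this position. For the compounds shown here, the only earlier single change concerned the aryl group on the ring nitrogen and stayed within the scatter, so this carbon is the first place where one change moves the number beyond the scatter. No measurement at hand accounts for the size of this step.

The step removes the aromatic ring and the hydroxyl together, so the compounds shown cannot separate the two; plain phenyl or 2-methoxyphenyl on this carbon, with the rest of compound 3 unchanged, would bear on that. Going by these compounds alone, also open is where a longer chain, an amine or a carboxylic acid at this carbon would fall relative to compound 3 and compound 4, since methyl and 2-hydroxyphenyl are the only two groups compared here on an otherwise identical core.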